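Removing one hydroxy from the dihydroxyphenyl ring

The compounds below may be only part of what the source reports. "The series", "measured", "known", "first", "only" and "open" are said of these compounds alone.

Measured compounds: compound 1 `O=C(/C(=C\c1ccc(O)cc1O)Sc1ccccc1Br)c1ccc(Cl)cc1` gives 50000 nM; compound 2 `O=C(/C(=C\c1ccc(OCc2ccccc2)cc1)SCc1ccc(Cl)cc1)c1ccc(Cl)cc1` gives 1000 nM; compound 3 `O=C(/C(=C\c1ccc(O)cc1O)SCc1ccc(Cl)cc1)c1ccc(Cl)cc1` gives 50000 nM, all in a functional assay on DU-145 cells (Homo sapiens) for inhibition, read by trypan blue exclusion, with a stated time of 96 h; on this read-out lower numbers stand for stronger inhibition of growth and higher numbers for weaker inhibition of growth.

Compound 3 stands level with compound 1 at the top of the three numbers, and the step of no change at the digits printed from compound 1 to compound 3 (within the scatter) shows that exchanging the group on the sulfur did nothing within the scatter. Within the data shown here, compound 2, whose value is a much lower number, differs from compound 3 in more than one place, so no single step is recorded between them. Compound 4 `O=C(/C(=C\c1ccc(O)cc1)SCc1ccc(Cl)cc1)c1ccc(Cl)cc1` arises from compound 3 by the change (hydrogen in place of hydroxy on an aromatic carbon). Among the measured compounds shown here, no measured step touches this change directly; the only hint is that compound 2, which also lacks a hydroxy ortho to the large group, gives 1000 nM. On that basis compound 4 is expected to give a lower number than compound 3, by a step of about a 2.5-fold lower number from compound 3 to compound 4 (0.40 log units; beyond the scatter) in this assay. The estimate for compound 4 is 20000 nM, with a range from 5000 nM to 50000 nM.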

Compound 4, concentration for 50% growth inhibition: 10000 nM
Beside the measured number, compound 4's estimate is 2.0-fold (0.30 log units) above it; measured number inside the range.
By their numbers in this assay, from the lowest: compound 2; then compound 4; then compounds 1 and 3 (each within the scatter of the next).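

In this assay, among these compounds, the change from 2,4-dihydroxyphenyl to 4-hydroxyphenyl gives the first step at this position, a 5.0-fold lower number from compound 3 to compound 4 (0.70 log units; beyond the scatter), so the hydroxy ortho to a large group matters here in a way the exchange on the sulfur could not show. Going by these compounds, the hydroxy that remains is also open to change, since hydrogen in place of benzyl on that oxygen gives a 10-fold higher number from compound 2 to compound 4 (1.00 log units; beyond the scatter), and the two steps together place compound 4 on a line running through both ring substitutions. Nothing among the data shown accounts for either step.

The compounds shown leave open whether a methoxy or an amine at the vacated place would behave like hydrogen or like hydroxy, and whether the same removal would give a similar step with 2-bromophenyl on the sulfur. They also leave open whether a methyl or a longer chain on the oxygen would do what benzyl does.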